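Extending the terminal aryl: methyl to tert-butyl

The source may hold more compounds than are shown below. What is called first, only, known or untested is meant among the compounds shown, and "the series" means these compounds.

Compound 2 `COc1cc2nc(N3CCN(S(=O)(=O)c4ccc(-c5ccc(C)cc5)cc4)CC3)nc(N)c2cc1OC` holds the lowest number of the two measured in a functional assay on PC-3 cells (Homo sapiens) for inhibition (a lower number here means a stronger inhibitor, a higher number a weaker inhibitor), with compound 2 giving 3400 nM. Among the measured compounds shown here, its only neighbour is compound 1 `COc1cc2nc(N3CCN(S(=O)(=O)c4ccc(C(=O)O)cc4)CC3)nc(N)c2cc1OC`, and in this assay compound 1 gives 53000 nM. For the measured compounds named here, the one measured step, a 16-fold lower number from compound 1 to compound 2 (1.19 log units; beyond the scatter), shows that exchanging the carboxy for a 4-methylphenyl on the sulfonyl-bearing ring moved the number far beyond the scatter.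

Compound 3 `COc1cc2nc(N3CCN(S(=O)(=O)c4ccc(-c5ccc(C(C)(C)C)cc5)cc4)CC3)nc(N)c2cc1OC` differs from compound 2 by tert-butyl in place of methyl on an aromatic carbon. Going by the values given here, no measured step touches this terminal ring directly; the only step available, a 16-fold lower number from compound 1 to compound 2 (1.19 log units; beyond the scatter), concerns a different position and cannot settle the direction here. The expectation is therefore a step of modest size, a 1.4-fold lower number from compound 2 to compound 3 (0.13 log units; within the scatter), within or close to the scatter. Compound 3 is estimated at 2500 nM in this assay, with a range from 800 nM to 8000 nM.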

Compound 3, half-maximal inhibitory concentration: 10000 nM
Beside the measured number, compound 3's estimate is 4.0-fold (0.60 log units) below it; the whole stated range lies below it.
By their numbers in this assay, from the lowest: compound 2; then compound 3; then compound 1.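

Among the compounds shown here, the change from methyl to tert-butyl is the first one measured on the terminal ring, and in this assay it gives a 2.9-fold higher number from compound 2 to compound 3 (0.47 log units; beyond the scatter) rather than an improvement, so the number at this position does respond to the group placed there. The terminal ring still keeps part of its advantage over the carboxy group, with a 5.3-fold lower number from compound 1 to compound 3 (0.72 log units; beyond the scatter) as the step, but 4-(tert-butyl)phenyl gives back some of what 4-methylphenyl gained. Nothing in the material shown explains why the number rises at this position.

From the compounds shown here alone, with only methyl and tert-butyl at this place, it remains open whether the number follows the size of the group or depends on tert-butyl alone. Going by these compounds, it also remains open whether an ethyl chain, an amine or a carboxylic acid on the terminal ring would give a number lower than that of compound 2.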